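Swapping pyrrolidin-1-yl for pentyloxy at a cytotoxicity limit

This account rests on a few compounds, and the source may have more. Where it says the series, first, only, none or still open, it means among the compounds named here.

Compound 1 `C=CCOc1nc(N)nc2c1ncn2/C=C1/CC1(CO)CO` and compound 2 `Nc1nc(N2CCCC2)c2ncn(/C=C3/CC3(CO)CO)c2n1` share one core and differ in a single group on an aromatic carbon. In an ADME assay on CCRF-HSB-2 cells (Homo sapiens) for cytotoxicity, with a stated time of 7 days (on this read-out lower numbers stand for higher toxicity in this test and higher numbers for lower toxicity in this test), compound 2 gives > 20000 nM, which is a limit of the assay and not a number. In this assay compound 1 gives > 20000 nM, which is also a limit. Both results stand at the limit of > 20000 nM in this assay, at which 2 of the 2 values shown sit, so neither compound has an exact value.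

The next change leads to compound 3 `CCCCCOc1nc(N)nc2c1ncn2/C=C1/CC1(CO)CO`: pentyloxy in place of pyrrolidin-1-yl on an aromatic carbon. Pentyloxy replaces pyrrolidin-1-yl on the same aromatic carbon. Going by the values given here, the one measured step that bears on this change is a step that the two limits leave unreadable from compound 1 to compound 2, and it involves the same position. Its size cannot be read, so it offers no number to carry over. Neither allyloxy in compound 1 nor pyrrolidin-1-yl in compound 2 gave a measurable value, so no step beyond the scatter is expected. The estimated step is a step that the limit leaves unreadable from compound 2 to compound 3. For compound 3 the estimate is 25000 nM, with an expected range of 9000 nM to 60000 nM, and a result reported only as a limit is the likeliest outcome.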

Compound 3, half-maximal cytotoxic concentration: > 20000 nM
Compound 3: a limit, no number (the forecaster's own chance of this, stated with the estimate: 70%); the middle value does not contradict the limit.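

The steps among compound 1, compound 2 and compound 3 cannot be read, since all three results are limits of the assay and not numbers: the limit of > 20000 nM in this assay, at which 3 of the 3 values shown sit. The compounds shown leave open whether in this assay allyloxy, pyrrolidin-1-yl and pentyloxy differ at all, and what exact value each compound would give.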